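Epimer at the Ring Carbon: Expected Cytotoxicity of Compound 3

The source may report more compounds than this note shows. Statements on the series, on what has been measured and on what is new or still open speak of the compounds shown alone.

Measured compounds:
compound 1, `O=[N+]([O-])c1cn2c(n1)[S@@+]([O-])C[C@@H](OCc1ccc(OC(F)(F)F)cc1)C2` — > 10 ug/mL
compound 2, `O=[N+]([O-])c1cn2c(n1)[S+]([O-])CC(OCc1ccc(OCc3ccccc3)cc1)C2` — > 10 ug/mL

Of the compounds shown here, two have been tested in an ADME assay on L929 cells (Mus musculus) for cytotoxicity; on this read-out lower numbers stand for stronger inhibition and higher numbers for weaker inhibition. Compound 1 gives > 10 ug/mL, which is a limit of the assay and not a number. Compound 2 gives > 10 ug/mL, likewise a limit. Among the compounds with values here, both results therefore sit at the limit of > 10 ug/mL in this assay, at which 2 of the 2 values shown sit, so compound 1 stands at the same limit as the only other measured compound, and the data separate nothing between them. Within the data shown here, no step between two measured compounds that differ in one place is available.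

Compound 3, `O=[N+]([O-])c1cn2c(n1)[S@@+]([O-])C[C@H](OCc1ccc(OC(F)(F)F)cc1)C2`, is not yet measured. It differs from compound 1 as follows: the two compounds have the same atoms and bonds and differ only in configuration as drawn: 1 of 2 stereo elements differ; a stereocentre at a saturated ring carbon is drawn S in compound 1 and R in compound 3. Among the measured compounds shown here, with both measured values sitting at the limit, there is no measured step to lean on. The step that the limit leaves unreadable from compound 1 to compound 3 is expected to be none beyond the usual scatter. Compound 3 is accordingly estimated at 15 ug/mL, with a range from 7 ug/mL to 40 ug/mL, and the result is expected most likely to be reported again only as a limit.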

Compound 3, half-maximal inhibitory concentration: > 10 ug/mL
Compound 3: a limit, no number (the forecaster's own chance of this, stated with the estimate: 80%); the middle value lies beyond the limit too.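

In this assay compound 3 gives > 10 ug/mL, which is a limit of the assay and not a number. No step can be read between compound 1 and compound 3, which differ only at a saturated ring carbon: the limit of > 10 ug/mL in this assay, at which 3 of the 3 values shown sit. The compounds shown leave open whether that configuration matters for cytotoxicity at all.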